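Triazole Aryl Swap on a Scaffold Without Cytotoxic Signal

The source may report more compounds than this note shows. Statements on the series, on what has been measured and on what is new or still open speak of the compounds shown alone.

Measured compounds:
Compound 1 `C=C1C[C@]23C[C@@]1(O)CC[C@@H]2c1cccc(C)c1[C@@H]3Cn1cc(-c2ccc(OC)cc2)nn1` gives > 20000 nM in a functional assay on A549 cells (Homo sapiens) for cytotoxicity, read by MTT assay, with a stated time of 4 days (a lower number here means a stronger inhibitor, a higher number a weaker inhibitor), a limit of the assay.
Compound 2 `C=C1C[C@]23C[C@@]1(O)CC[C@H]2c1ccc(O)c(C)c1[C@@H]3Cn1cc(-c2ccc(Br)cc2)nn1` gives > 20000 nM in this assay, also a limit.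
Compound 3 `COc1ccc(-c2cn(C[C@H]3c4c(ccc(OS(=O)(=O)c5ccc(C)cc5)c4C)[C@@H]4CC[C@@]5(C)C[C@]43CC5=O)nn2)cc1` gives > 20000 nM in this assay, again a limit.

Compound 1 therefore stands at the assay limit rather than at a number, and all values shown sit there (the limit of > 20000 nM in this assay, at which 3 of the 3 values shown sit). Among the measured compounds shown here, no two measured compounds differ in a single place, so no measured step exists. Compound 4 `C=C1C[C@]23C[C@@]1(O)CC[C@@H]2c1cccc(C)c1[C@@H]3Cn1cc(-c2ccccn2)nn1` differs from compound 1 by pyridin-2-yl in place of 4-methoxyphenyl on an aromatic carbon. With every value at the limit, the step in this assay from compound 1 to compound 4 is expected to be none beyond the scatter, most likely another limit. Compound 4 is estimated at 25000 nM, between 8000 nM and 80000 nM. The expected step that the limit leaves unreadable from compound 1 to compound 4 is nominal only.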

Compound 4, half-maximal inhibitory concentration: > 20000 nM
Compound 4: only a limit was reported; the forecaster's own chance of this, stated with the estimate: 85%; the middle value does not contradict the limit.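

Compound 4 gives > 20000 nM in this assay, a limit of the assay. With compound 1 also at a limit, the step between these two compounds cannot be read. The compounds shown leave open whether any change to the shared core would give a measurable value rather than a limit.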